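The source may hold more compounds than are shown below. What is called first, only, known or untested is meant among the compounds shown, and "the series" means these compounds.

The measured compounds, each with its activity in a functional assay on the whole organism (Tail, strain ICR) with Mus musculus as the target, in the tail flick test, with a stated time of 60 min, at a dose of 25 umol/kg by the oral route; on this read-out lower numbers stand for a weaker effect and higher numbers for a stronger effect at the one dose given:

compound 1, `O=C(O)C[C@H](NC(=O)CN(c1nc(Cl)nc2[nH]cnc12)C1CC1)C(=O)O`, 38.9%
compound 2, `NC(=O)CC[C@H](NC(=O)CN(c1nc(Cl)nc2[nH]cnc12)C1CC1)C(=O)O`, 38.4%
compound 3, `NC(=O)CC[C@H](NC(=O)CN(c1nc(Cl)nc2[nH]cnc12)C1CC1)C(=O)OCc1ccccc1`, 33.1%

All three share a common core and differ only in the amino-acid part attached to it. Compound 2 sits in the middle of the three numbers, but neither neighbour is separated from it by more than the usual scatter: the step of a number 0.5 percentage points lower from compound 1 to compound 2 (within the scatter) and the step of a number 5.3 percentage points lower from compound 2 to compound 3 (within the scatter) are both too small to count as real differences. On this basis the three compounds look alike in this assay.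

Compound 4, `CC[C@H](C)[C@H](NC(=O)CN(c1nc(Cl)nc2[nH]cnc12)C1CC1)C(=O)O`, has not yet been measured. It differs from compound 2 by sec-butyl in place of 2-carbamoylethyl on a saturated chain carbon bound to an amide-type nitrogen and a carbonyl carbon. The change at this position in the measured set, from compound 1 to compound 2, swapped one polar group for another and left the read-out unchanged within the scatter; the step from compound 2 to compound 3 touched a different place and was also within the scatter. For the measured compounds named here, no measured step replaces a polar side chain with a plain hydrocarbon one, so the data give no direction for this change. The estimate for compound 4 is therefore a number close to that of compound 2, 35%, within 20% to 50%, which means an expected step of a number 3.4 percentage points lower from compound 2 to compound 4 (within the scatter) that would not exceed the scatter.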

Compound 4, a percentage reported as activity, at one dose (the size of the read-out at that dose, not a potency): 36%
Compound 4: middle estimate off by 1 percentage points, on the low side, and the stated range covers the measured number.
By their numbers in this assay, from the lowest: compounds 3, 4, 2 and 1 (each within the scatter of the next).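

In this assay, placing sec-butyl on the saturated chain carbon bound to an amide-type nitrogen and a carbonyl carbon gives a number 2.4 percentage points lower from compound 2 to compound 4 (within the scatter) and a number 2.9 percentage points lower from compound 1 to compound 4 (within the scatter). Until now, this position had only seen one side chain containing oxygen exchanged for another, whereas sec-butyl contains carbon atoms only and has no hydrogen-bond donors or acceptors. The read-out therefore does not depend on the hydrogen-bond donor and acceptor of 2-carbamoylethyl, or on any nitrogen or oxygen in the side chain, since the step stays within the scatter; no measurement at hand explains why the side chain can vary in this way.

The compounds shown leave open whether an amine at the end of a longer chain, a phenyl ring or a lone methyl group at this position would keep the read-out within the scatter of these values. They also leave open whether compounds that look alike at this single dose would still look alike across a range of doses.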